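A few compounds are considered here, and "the series" means these few. Any claim that something is new, unique, unknown or untested is made for them only; others in the source may bear on it.

Measured compounds, growth inhibition on prostate carcinoma cells:

compound 1 `COc1ccc(C(=O)/C(=C\c2ccc(OC)c(O)c2)Sc2ccc(F)cc2)cc1`: 1000 nM
compound 2 `COc1ccc(/C=C(/SCc2ccc(F)cc2)C(=O)c2ccc(Br)cc2)cc1O`: 1000 nM
compound 3 `COc1ccc(C(=O)/C(=C\c2ccc(Br)cc2)Sc2ccc(F)cc2)cc1`: > 100000 nM

In a functional assay on DU-145 cells (Homo sapiens) for inhibition, read by trypan blue exclusion, with a stated time of 96 h (on this read-out higher numbers stand for weaker inhibition of growth and lower numbers for stronger inhibition of growth), compound 1 gives 1000 nM and compound 2 gives 1000 nM; the two sit level at the digits shown, within the usual scatter, so no order is read between them. The difference between the core of compound 1 and the core of compound 2 is not broken down here.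

In this assay compound 3 gives > 100000 nM, which is a limit of the assay and not a number. The change from compound 1 to compound 3 is 4-bromophenyl in place of 3-hydroxy-4-methoxyphenyl on a double-bonded chain carbon bound to a double-bonded chain carbon. Its step is an at least 100-fold higher number from compound 1 to compound 3 (2.00 log units; beyond the scatter); its size is bounded only because the limit of > 100000 nM in this assay, at which 1 of the 3 values shown sits, is all that is known on the upper side.

Compound 4 `O=C(/C(=C\c1ccc(Br)cc1)SCc1ccc(F)cc1)c1ccc(Br)cc1` has not yet been measured in this assay. It relates to compound 2 as compound 3 relates to compound 1: 4-bromophenyl in place of 3-hydroxy-4-methoxyphenyl on a double-bonded chain carbon bound to a double-bonded chain carbon. The place is the same, so this is the same change, made a second time in the series.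

The expectation rests on compound 3, whose value > 100000 nM is a limit, and on compound 2 sitting level with compound 1. A step of about a 150-fold higher number from compound 2 to compound 4 (2.18 log units; beyond the scatter) is expected from compound 2 to compound 4. Compound 4 is expected near 150000 nM, roughly between 30000 nM and 1000000 nM, and quite possibly reported as a limit only. Only two examples of this change exist among these compounds, so the expectation carries that caveat.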

Compound 4, concentration for 50% growth inhibition: 25000 nM
The estimate for compound 4 lay 6.0-fold (0.78 log units) above the measured number; the measured number lies below the stated range.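

In this assay the change to 4-bromophenyl in place of 3-hydroxy-4-methoxyphenyl on a double-bonded chain carbon bound to a double-bonded chain carbon gives a higher number on both cores, and on the core of compound 2 the step is a 25-fold higher number from compound 2 to compound 4 (1.40 log units; beyond the scatter); the direction carries over, but the size does not carry over unchanged: the same change on two cores in this assay, an at least 100-fold higher number (2.00 log units; beyond the scatter) from compound 1 to compound 3 and a 25-fold higher number (1.40 log units; beyond the scatter) from compound 2 to compound 4, at least 4.0-fold (0.60 log units) apart, beyond the scatter of two such steps.

Compound 3 stands at > 100000 nM, which is a limit of the assay and not a number, so the step on the core of compound 1 has a bound and no exact size: the limit of > 100000 nM in this assay, at which 1 of the 4 values shown sits.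

The two cores differ in more than one place, so this pair does not show which part of the core goes with the difference in step size, and two examples set no rule for any further core.

Still open, as far as these compounds go, is whether the higher number goes with the loss of the hydroxy group, the methoxy group or both, a question that a 3-hydroxyphenyl or a 4-methoxyphenyl in the same place on each core would address. Also open, from the compounds shown here alone, is how an amine or a carboxylic acid in that place would read in this assay.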